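The source may hold more compounds than are shown below. What is called first, only, known or untested is meant among the compounds shown, and "the series" means these compounds.

Working notes on the series.

Compound 1 `N#Cc1ccccc1-c1nc2cccnc2o1` gives 61% in a functional assay on the whole organism for inhibition, with Rattus norvegicus as the target, at a dose of 30 mg/kg; a higher number here means more inhibition at the dose given (going by the name of the read-out), a lower number less inhibition. Compound 3 `O=[N+]([O-])c1ccccc1-c1nc2cccnc2o1` differs from it by nitro in place of cyano on an aromatic carbon, and in this assay compound 3 gives 57%, so the step of a number 4 percentage points lower from compound 1 to compound 3 (within the scatter) leaves the two within the scatter of one another. Compound 2 `N#Cc1cccc(-c2nc3ncccc3o2)c1` has the same atoms as compound 1 joined differently; the difference between the two cores is not broken down here. In this assay compound 2 gives 21%, the lowest of the three numbers, beyond the scatter from both compound 3 and compound 1.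

Compound 4 `O=[N+]([O-])c1cccc(-c2nc3ncccc3o2)c1` is not yet measured. Among the measured compounds shown here, it differs from compound 2 by nitro in place of cyano on an aromatic carbon, which is the same kind of change as the one from compound 1 to compound 3, not the same: in compound 4 the nitro stands meta to a group of 9 heavy atoms, in compound 3 ortho to a group of 9 heavy atoms. For the measured compounds named here, only one measured instance of the change exists, on a different core, so the expectation rests on it alone.

The step from compound 2 to compound 4 is expected to be a number 3 percentage points lower from compound 2 to compound 4 (within the scatter), because the step of a number 4 percentage points lower from compound 1 to compound 3 (within the scatter) was within the scatter. Compound 4 is estimated at 18% in this assay, most likely between 5% and 38%.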

Compound 4, a percentage reported as inhibition, in the whole organism at one dose (the size of the read-out at that dose, not a potency): 21%
Beside the measured number, compound 4's estimate is 3 percentage points below it; the measured number falls inside the stated range.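

On the second core the exchange of cyano for nitro on an aromatic carbon, here meta to a group of 9 heavy atoms, gives in this assay no change at the digits printed from compound 2 to compound 4 (within the scatter). Set beside the earlier step, the exchange reads the same on both cores, so in these two pairs the nitro and cyano compounds can be treated as interchangeable in this read-out: the same change on two cores in this assay, a number 4 percentage points lower (within the scatter) from compound 1 to compound 3 and no change at the digits printed (within the scatter) from compound 2 to compound 4, 4 percentage points apart, within the scatter of two such steps. Among the compounds shown here, this shows only that the exchange left the read-out within the scatter on these two cores, at one dose in the whole organism; two pairs give no rule for any further core, and neither step says anything about what separates the two cores or why the exchange leaves the number in place.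

The compounds shown carry only cyano or nitro on the carbon-only aromatic ring, so it remains open how an amine, a carboxylic acid or a longer chain in the same place would read in this assay. Also open, from the compounds shown here alone, is whether the agreement between the two steps would hold on a third core or at another dose.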